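The source may report more compounds than this note shows. Statements on the series, on what has been measured and on what is new or still open speak of the compounds shown alone.

Measured compounds:
compound 1, `COc1cc(-c2nn(-c3cccc(NC(=O)c4cccc(C(F)(F)F)c4)c3)cc2-c2ccncc2)ccc1Cl` — > 50000 nM
compound 2, `COc1cc(-c2nn(-c3cccc(NC(=O)c4ccc(Cl)c(C(F)(F)F)c4)c3)cc2-c2ccncc2)ccc1Cl` — > 32500 nM

In a functional assay on LOX IMVI cells (Homo sapiens) for inhibition, read by sulforhodamine B assay, with a stated time of 48 h (on this read-out lower numbers stand for stronger inhibition of growth and higher numbers for weaker inhibition of growth), compound 1 gives > 50000 nM, which is a limit of the assay and not a number. In the same assay compound 2 gives > 32500 nM, again a limit rather than a number. Within the data shown here, the only measured step, a step that the two limits leave unreadable from compound 1 to compound 2, therefore cannot be read in size or direction. Compound 2 stands at the limit of > 32500 nM in this assay, at which 1 of the 2 values shown sits, with the other value, that of compound 1, sitting at the limit of > 50000 nM in this assay, at which 1 of the 2 values shown sits; on the numbers shown, compound 2 is no better placed than a limit allows.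

Compound 3, `COc1cc(-c2nn(-c3cccc(NC(=O)Nc4ccc(Cl)c(C(F)(F)F)c4)c3)cc2-c2ccncc2)ccc1Cl`, has not yet been measured. It differs from compound 2 by (4-chloro-3-(trifluoromethyl)phenyl)amino in place of 4-chloro-3-(trifluoromethyl)phenyl on a carbonyl carbon. Among the measured compounds shown here, no measured step bears on this kind of change, and the one step available, between compound 1 and compound 2, is itself unreadable. With both measured compounds at limits, compound 3 is expected to remain weak, and the step of an at least 1.0-fold lower number from compound 2 to compound 3 (0.03 log units; that floor lies within the scatter) is estimated to be small or not readable beyond the scatter. Compound 3 is expected to give about 30000 nM, within a range of 5000 nM to 100000 nM, most likely reported again as a limit.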

Compound 3, concentration for total growth inhibition: 4610 nM
Compound 3: the middle estimate sits 6.5-fold (0.81 log units) above what was measured; measured number below the stated range.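

In this assay, (4-chloro-3-(trifluoromethyl)phenyl)amino in place of 4-chloro-3-(trifluoromethyl)phenyl on a carbonyl carbon gives an at least 7.0-fold lower number from compound 2 to compound 3 (0.84 log units; beyond the scatter), and the comparison with the unchlorinated partner gives an at least 10-fold lower number from compound 1 to compound 3 (1.03 log units; beyond the scatter). Compound 3 gives 4610 nM, the first value in this short series that is a number and not a limit, so the carbonyl carbon is the first place shown where a change moves growth inhibition readably. Both sizes are only floors, because compound 2 stands at a limit of the assay: the limit of > 32500 nM in this assay, at which 1 of the 3 values shown sits.

The chloro step between compound 1 and compound 2 cannot be read, and how far the other steps run past their floors stays open, since compound 1 also stands at a limit of the assay: the limit of > 50000 nM in this assay, at which 1 of the 3 values shown sits. Whether the drop in the number depends on the added nitrogen itself also stays open, as the compounds shown include no partner with an oxygen or a methylene in its place, and none that shows whether the 3-(trifluoromethyl)phenyl group would respond to the same change without its chloro.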